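The source may hold more compounds than are shown below. What is called first, only, known or untested is meant among the compounds shown, and "the series" means these compounds.

In a functional assay on microsomes from liver (Rattus norvegicus) for inhibition (on this read-out higher numbers stand for weaker inhibition and lower numbers for stronger inhibition), compound 1 `COc1ccc2c(c1)CCC(Cc1ccc(O)cc1)C2=O` gives 400 nM. For the measured compounds named here, compound 2 `O=C1c2ccc(O)cc2CCC1Cc1ccc(O)cc1` gives 1500 nM, the higher of the two true numbers so far. Between them lies a 3.8-fold higher number from compound 1 to compound 2 (0.57 log units; beyond the scatter), for hydrogen in place of methyl on an oxygen on an aromatic ring. Compound 3 `O=C1/C(=C/c2ccc(-c3ccccc3)cc2)CCc2cc(O)ccc21` reads > 20000 nM, which is a limit of the assay and not a number.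

Compound 4 `O=C1c2ccc(O)cc2CCC1Cc1ccc(-c2ccccc2)cc1` keeps the frame of compound 2 but has phenyl in place of hydroxy on an aromatic carbon, para to a large group (phenyl in place of hydroxy on an aromatic carbon). Going by the values given here, the one measured step concerns a different place in the molecule, so it offers only a modest yardstick and no direct measure of this change. The closest pointer is compound 3 , which also carries phenyl on an aromatic ring, though it differs elsewhere too, and its reading of > 20000 nM is a limit. Weaker inhibition is therefore expected, with an estimated 4.0-fold higher number from compound 2 to compound 4 (0.60 log units; beyond the scatter). For compound 4 the expected value is 6000 nM, with an estimated range of 1200 nM to 20000 nM.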

Compound 4, half-maximal inhibitory concentration: 800 nM
Estimate against measurement, compound 4: 7.5-fold (0.88 log units) above; the whole stated range lies above it.
By their numbers in this assay, from the lowest: compounds 1, 4 and 2 (each within the scatter of the next, the first and the last beyond it). At a limit, above all of these: compound 3.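

In this assay, the hydroxy para to a large group can give way to phenyl with no reading of the change beyond the scatter: a 1.9-fold lower number from compound 2 to compound 4 (0.27 log units; within the scatter). This position therefore accepts a six-membered aromatic ring of carbon only, and the hydrogen-bond donor and acceptor that leave with the hydroxy are not needed for a reading in this range. Compound 4 carries phenyl without sitting at a limit, whereas compound 3, which also carries phenyl, gives a reading that is a limit and not a number: the limit of > 20000 nM in this assay, at which 1 of the 4 values shown sits.

On these data alone, whether the position would also take an amine or a carboxylic acid remains open. The step at the other oxygen, a 3.8-fold higher number from compound 1 to compound 2 (0.57 log units; beyond the scatter), is shown only with hydroxy at this position, so whether it holds with phenyl there also stays open.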